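Trimming the Side Chain Down to a Bare Methyl

The compounds below may be only part of what the source reports. "The series", "measured", "known", "first", "only" and "open" are said of these compounds alone.

Three measured compounds share one core and differ only in the side chain of the amino acid part. In a functional assay on the whole organism (Tail, strain ICR) with Mus musculus as the target, in the tail flick test, with a stated time of 120 min, at a dose of 25 umol/kg by the oral route (a lower number here means a weaker effect, a higher number a stronger effect of the compound at the dose given), compound 1 `O=C(CN(c1nc(Cl)nc2[nH]cnc12)C1CC1)N[C@@H](CO)C(=O)O` gives 39%, compound 2 `NCCCC[C@H](NC(=O)CN(c1nc(Cl)nc2[nH]cnc12)C1CC1)C(=O)O` gives 16.4%, and compound 3 `O=C(O)C[C@H](NC(=O)CN(c1nc(Cl)nc2[nH]cnc12)C1CC1)C(=O)O` gives 22%. Compound 3 stands second highest of the three: a number 5.6 percentage points higher from compound 2 to compound 3 (within the scatter), while a number 17 percentage points lower from compound 1 to compound 3 (beyond the scatter). Compound 4 `C[C@H](NC(=O)CN(c1nc(Cl)nc2[nH]cnc12)C1CC1)C(=O)O` carries hydrogen in place of carboxy on a saturated chain carbon, two bonds along the chain from an amide-type nitrogen and a carbonyl carbon. Going by the values given here, no measured step removes a group outright; the nearest guides are a number 17 percentage points lower from compound 1 to compound 3 (beyond the scatter) and a number 22.6 percentage points lower from compound 1 to compound 2 (beyond the scatter), both showing that replacing hydroxy lowered the number. Whether removing carboxy entirely recovers part of that is not shown, so only a small rise is expected, a number 6 percentage points higher from compound 3 to compound 4 (within the scatter). Compound 4 is therefore expected to give 28%, within a range from 12% to 45%.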

Compound 4, a percentage reported as activity, at one dose (the size of the read-out at that dose, not a potency): 28.4%
The estimate for compound 4 lay 0.4 percentage points below the measured number; low and high end bracket the measured number.
By their numbers in this assay, from the lowest: compounds 2, 3 and 4 (each within the scatter of the next, the first and the last beyond it); then compound 1.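

With the side chain cut down to a bare methyl, this position now has a simple reference point. In this assay, the change from carboxymethyl to methyl gives a number 6.4 percentage points higher from compound 3 to compound 4 (within the scatter), so the carboxy can go without a clear gain or loss. Measured from the methyl, the longer chain bearing an amine costs activity, a number 12 percentage points higher from compound 2 to compound 4 (beyond the scatter), while the hydroxy adds some, since trading it for hydrogen gives a number 10.6 percentage points lower from compound 1 to compound 4 (beyond the scatter).

As far as these compounds go, whether an isopropyl or a benzyl group at this position would match or pass the hydroxy stays open. Nothing given here explains these differences.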